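Replacing 4-methoxyphenyl with 1H-indol-5-yl in the series

This account rests on a few compounds, and the source may have more. Where it says the series, first, only, none or still open, it means among the compounds named here.

Going by the values given here, only two compounds have been measured so far in a functional assay on K562 cells (Homo sapiens) for inhibition, read by trypan blue exclusion, with a stated time of 72 h; a lower number here means a stronger inhibitor, a higher number a weaker inhibitor. Compound 2 (`COc1ccc(Nc2ncc3cc(S(=O)(=O)c4ccc(Cl)cc4)c(=O)n(C)c3n2)cc1`) stands at 15000 nM, the higher of the two numbers and so the weaker inhibitor. Compound 1 (`Cn1c(=O)c(S(=O)(=O)c2ccc(C(=O)O)cc2)cc2cnc(Nc3ccc4[nH]ccc4c3)nc21`) lies at 5000 nM, a lower number by a gap beyond the scatter.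

Compound 3 (`Cn1c(=O)c(S(=O)(=O)c2ccc(Cl)cc2)cc2cnc(Nc3ccc4[nH]ccc4c3)nc21`) changes one group of compound 2: 1H-indol-5-yl in place of 4-methoxyphenyl on a nitrogen on an aromatic ring. It places 1H-indol-5-yl in place of 4-methoxyphenyl on a nitrogen on an aromatic ring.

Among the compounds with values here, no measured pair shows this change alone, so the step has no direct precedent. Within the data shown here, the only pointer is compound 1, which also carries the (1H-indol-5-yl)amino group and gives 5000 nM in this assay, although it is not a clean comparison for this change. A moderate move towards a lower number is therefore expected, and the estimate remains uncertain. The estimated step is a 5.0-fold lower number from compound 2 to compound 3 (0.70 log units; beyond the scatter), expected to lie beyond the scatter. Compound 3 is expected at 3000 nM, with an estimated range from 400 nM to 12000 nM in this series.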

Compound 3, half-maximal inhibitory concentration: 100 nM
For compound 3 the middle estimate is 30-fold (1.48 log units) above the measured one; the measured number lies below the stated range.
By their numbers in this assay, from the lowest: compound 3; then compound 1; then compound 2.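

In this assay, the change from (4-methoxyphenyl)amino to (1H-indol-5-yl)amino, with the chloro group held constant, gives a 150-fold lower number from compound 2 to compound 3 (2.18 log units; beyond the scatter); the group on this nitrogen on an aromatic ring therefore has a large effect on the number in this pair. With 1H-indol-5-yl held constant, chloro in place of carboxy on an aromatic carbon gives a 50-fold lower number from compound 1 to compound 3 (1.70 log units; beyond the scatter), so this second place also produces a large step and compound 1 did not show how low the number could go with 1H-indol-5-yl present. Nothing on hand accounts for either step.

The compounds shown leave open whether the first step depends on the hydrogen-bond donor of 1H-indol-5-yl or on the two-ring group as a whole, a question that a methyl on the indole nitrogen or a plain naphthyl group would help to separate. They also leave open how other groups at the chloro place, such as a primary amide or a methyl ester, would compare with chloro and carboxy alongside 1H-indol-5-yl.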